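This account rests on a few compounds, and the source may have more. Where it says the series, first, only, none or still open, it means among the compounds named here.

Measured so far in a physicochemical assay for solubility, read by chemiluminescence, in phosphate buffer, measured as kinetic solubility, at pH 7.4; a lower number here means a less soluble compound, a higher number a more soluble compound:
Compound 1 `Cc1cnc(Nc2ccc(C(=O)NCC3(c4nc(-c5ccccc5)cs4)CCOCC3)cc2)s1`: < 1000 nM (a limit)
Compound 2 `Cc1cc(C)n(-c2ccc(C(=O)NCC3(c4nc(-c5ccccc5)cs4)CCOCC3)cc2)n1`: 33000 nM

Within the data shown here, compound 2 holds the only actual number so far, 33000 nM. Compound 1 gives < 1000 nM, which is a limit and not a number, as the limit of < 1000 nM in this assay, at which 1 of the 2 values shown sits, records.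

Compound 3 `O=C(NCC1(c2nc(-c3ccccc3)cs2)CCOCC1)c1ccc(-n2ccnc2)cc1` carries 1H-imidazol-1-yl in place of 3,5-dimethyl-1H-pyrazol-1-yl (1H-imidazol-1-yl in place of 3,5-dimethyl-1H-pyrazol-1-yl on an aromatic carbon). Among the measured compounds shown here, the one measured step that bears on this is an at least 33-fold higher number from compound 1 to compound 2 (1.51 log units; beyond the scatter). That step was large and beyond the scatter, but it exchanged a different group, so it sets no size for this change. Here, one five-membered aromatic ring with 2 hetero atoms replaces another. A small upward step in this assay, not clearly beyond the scatter, is therefore expected. The estimated step is a 1.4-fold higher number from compound 2 to compound 3 (0.13 log units; within the scatter). Compound 3 is expected at 45000 nM, with an estimated range of 12000 nM to 120000 nM.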

Compound 3, solubility: 193000 nM
The estimate for compound 3 lay 4.3-fold (0.63 log units) below the measured number; measured number outside the range, above it.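

In this assay, 1H-imidazol-1-yl in place of 3,5-dimethyl-1H-pyrazol-1-yl gives a 5.8-fold higher number from compound 2 to compound 3 (0.77 log units; beyond the scatter). This shows that the place on the aromatic carbon, para to a large group, still responds when one five-membered aromatic ring with 2 hetero atoms replaces another, with the counts of hydrogen-bond donors and acceptors unchanged. The value of compound 1 is a limit and not a number, and the widest step in the series, an at least 190-fold higher number from compound 1 to compound 3 (2.28 log units; beyond the scatter), has to be read with that in mind.

The two rings differ both in their two methyl groups and in the arrangement of their nitrogens, so the step does not tell which of these matters. From the compounds shown here alone, a plain 1H-pyrazol-1-yl group would separate the two, and how an amine or a carboxylic acid at this place would read remains open.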